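The source may report more compounds than this note shows. Statements on the series, on what has been measured and on what is new or still open speak of the compounds shown alone.

Compound 1 `O=C(NO)c1cc(F)c(Cn2nnc(-c3ccco3)n2)c(F)c1` and compound 2 `Nc1ccc(-c2nnn(Cc3c(F)cc(C(=O)NO)cc3F)n2)cc1` share one core and differ only in the group attached to it. In an assay on Sf9 cells for inhibition of protein deacetylase HDAC6 (Homo sapiens), read by fluorescence (a higher number here means a weaker inhibitor, a lower number a stronger inhibitor), compound 1 gives 3 nM. Replacing the furan-2-yl group with a 4-aminophenyl group, no change at the digits printed from compound 1 to compound 2 (within the scatter), so compound 2 gives 3 nM and stands level with compound 1.

Compound 3 `NCc1ccc(-c2nnn(Cc3c(F)cc(C(=O)NO)cc3F)n2)cc1` has not been measured. It differs from compound 2 at the outer end of the molecule: aminomethyl in place of amino on an aromatic carbon. Among the compounds with values here, the one measured step that bears on this region, no change at the digits printed from compound 1 to compound 2 (within the scatter), shows that an exchange of the whole group attached to the core at this end left the result unchanged within the scatter. Since the change to compound 3 is smaller than that and keeps the same donor and acceptor count, no step beyond the scatter is expected; the estimated step of a 1.3-fold higher number from compound 2 to compound 3 (0.12 log units; within the scatter) is meant as flat. Compound 3 is therefore expected to give about 4 nM in this assay, with a range from 1.5 nM to 12 nM.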

Compound 3, half-maximal inhibitory concentration: 4 nM
Compound 3: the middle estimate sits on the measured number at the digits printed, and the stated range covers the measured number.
By their numbers in this assay, from the lowest: compounds 1, 2 and 3 (each within the scatter of the next).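

Moving from an amino group to an aminomethyl group on this aromatic carbon, para to a large group, gives a 1.3-fold higher number from compound 2 to compound 3 (0.12 log units; within the scatter) in this assay, so this small change in the group's length leaves the reading flat. Within the data shown here, the earlier pair showed only that one whole end group could be swapped for another; this pair shows that the amine on the phenyl ring can also be changed from amino to aminomethyl with the result staying within the scatter. The wider comparison with the furan-2-yl group gives a 1.3-fold higher number from compound 1 to compound 3 (0.12 log units; within the scatter) as its result, which means that the three end groups shown, furan-2-yl, 4-aminophenyl and 4-(aminomethyl)phenyl, cannot be told apart in this assay, and nothing available explains this tolerance.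

The compounds shown leave open whether the flat reading would hold for a longer chain such as aminoethyl or aminopropyl, for a tertiary amine such as dimethylamino, or for a carboxylic acid in the same place. They also leave open whether the same end groups would behave alike on a core carrying hydrogen in place of the two fluorines.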